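The source may hold more compounds than are shown below. What is called first, only, known or untested is meant among the compounds shown, and "the series" means these compounds.

Measured in a functional assay on A549 cells (Homo sapiens) for inhibition, read by MTT assay, with a stated time of 24 h; on this read-out higher numbers stand for weaker inhibition and lower numbers for stronger inhibition:
compound 1 `CCOC(=O)C1=Cc2ccccc2OC1(OCc1cn(-c2ccc(C)cc2)nn1)C(F)(F)F`: 19700 nM
compound 2 `CCOC(=O)C1=Cc2ccccc2OC1(OCc1cc(-c2ccc(Br)cc2)no1)C(F)(F)F`: > 150000 nM, reported as a limit of this assay and not as a number

Compound 1 holds the only actual number in this assay among the two compounds shown. Of the two values given, one is the limit of > 150000 nM in this assay, at which 1 of the 2 values shown sits; compound 2 is the one that sits there, and that entry is a limit only. No step between two measured compounds is available in this assay, so there is no measured change in the series to lean on, and nothing here points to a cause for either value.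

Compound 3 `CCCCCCCCn1cc(COC2(C(F)(F)F)Oc3ccccc3C=C2C(=O)OCC)nn1` differs from compound 1 in one place: octyl in place of 4-methylphenyl on an aromatic nitrogen. The change removes the ring group from the aromatic nitrogen and puts a chain there. Among the measured compounds shown here, with no measured step of comparable kind, the step from compound 1 to compound 3 in this assay is expected to be small, most likely a drift toward weaker inhibition that may well stay within the scatter, a 1.5-fold higher number from compound 1 to compound 3 (0.18 log units; within the scatter). For compound 3 the estimated value in this assay is 30000 nM, expected to fall between 8000 nM and 120000 nM.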

Compound 3, half-maximal inhibitory concentration: > 150000 nM
Compound 3: only a limit was reported; the forecaster's own chance of this, stated with the estimate: 25%; middle value at least 5.0-fold (0.69 log units) from the limit.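

In this assay, the aromatic nitrogen of the five-membered ring now has its first measured step, and this exchange is not neutral: octyl in place of 4-methylphenyl gives an at least 7.6-fold higher number from compound 1 to compound 3 (0.88 log units; beyond the scatter). Compound 3 gives > 150000 nM, which is a limit of the assay and not a number, and the step therefore fixes only a minimum size for the change: the limit of > 150000 nM in this assay, at which 2 of the 3 values shown sit. Neither group carries a net charge or counts any hydrogen-bond donors or acceptors, and what changes in this pair is the loss of one six-membered aromatic ring of carbon only and the entry of a chain with no ring.

As far as these compounds go, this single pair does not separate the loss of the ring from the length of the chain, and it remains open whether a shorter chain such as butyl, or a phenyl ring carrying an amine or a carboxylic acid, on the same nitrogen would give a number in this assay. Compound 2 differs from compound 1 in more than one place, and the part played by the five-membered ring with 3 nitrogen cannot be read from the compounds shown.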